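Series notes: the step from compound 1 to compound 4

The compounds below may be only part of what the source reports. "The series", "measured", "known", "first", "only" and "open" are said of these compounds alone.

Measured in a functional assay on HT-29 cells (Homo sapiens) for antiproliferative activity, read by sulforhodamine B assay, with a stated time of 72 h (on this read-out higher numbers stand for weaker inhibition and lower numbers for stronger inhibition), so far
- compound 1 `COc1ccccc1NC(=S)N/N=C/c1ccc2ccccc2n1` gives > 100000 nM (a limit)
- compound 2 `CN(C)C(=S)N/N=C/c1ccc2ccccc2n1` gives 20 nM
- compound 3 `NC(=S)N/N=C/c1cc2cccnc2s1` gives > 100000 nM (a limit)

Compound 1 sits at the limit of > 100000 nM in this assay, at which 2 of the 3 values shown sit. It therefore has no numerical value.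

Compound 4 `Cc1ccc(NC(=S)N/N=C/c2ccc3ccccc3n2)cc1` carries 4-methylphenyl in place of 2-methoxyphenyl on an amide-type nitrogen. Within the data shown here, no measured pair covers this change. Compound 1 shares its core with compound 2, and compound 2 gives 20 nM, so a modest expected step toward stronger inhibition in this assay is allowed. A result at the limit remains possible for compound 4. The expected change is an at least 5.0-fold lower number from compound 1 to compound 4 (0.69 log units; beyond the scatter). For compound 4 the estimated value is 20000 nM, with an expected range from 1500 nM to 100000 nM.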

Compound 4, half-maximal inhibitory concentration: 85500 nM
For compound 4 the middle estimate is 4.3-fold (0.63 log units) below the measured one; measured number inside the range.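

Compound 4 gives this position its first numerical reading with a substituted phenyl group on the amide-type nitrogen. The change reads as an at least 1.1-fold lower number from compound 1 to compound 4 (0.06 log units; that floor lies within the scatter), so no gain over 2-methoxyphenyl can be claimed. The step has only a floor because compound 1 carries a limit and not a number: the limit of > 100000 nM in this assay, at which 2 of the 4 values shown sit.

Open, on these data alone, is whether the methyl-for-methoxy swap or the different placement on the phenyl ring matters more, which a 4-methoxyphenyl group on this nitrogen would help to separate. Also open, as far as these compounds go, is how a non-aromatic amine such as morpholine would read there in this assay.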